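The source may report more compounds than this note shows. Statements on the series, on what has been measured and on what is new or still open speak of the compounds shown alone.

Among the measured compounds shown here, in a toxicity assay on MT4 cells (Homo sapiens) for cytotoxicity, read by MTT assay, with a stated time of 7 days (on this read-out higher numbers stand for lower toxicity in this test and lower numbers for higher toxicity in this test), compound 2 `Cc1cc(C)cc(S(=O)(=O)c2c(C(=O)NC3CC4(CCNCC4)C3)[nH]c3ccc(Cl)cc23)c1` gives 24200 nM, the only true number so far. Compound 1 `Cc1cc(C)cc(S(=O)(=O)c2c(C(=O)NC3CC4(C3)CN(S(C)(=O)=O)C4)[nH]c3ccc(Cl)cc23)c1` reports > 233000 nM, which is a limit of the assay and not a number. For the measured compounds named here, the one measured step is an at least 9.6-fold lower number from compound 1 to compound 2 (0.98 log units; beyond the scatter), and it exchanges the group on the amide-type nitrogen. Compound 3 `Cc1cc(C)cc(S(=O)(=O)c2c(C(=O)NC3CC4(CCN(CC(N)=O)C4)C3)[nH]c3ccc(Cl)cc23)c1` changes that same place: a group of 12 heavy atoms (9 carbon, 2 nitrogen, 1 oxygen; one four-membered non-aromatic ring of carbon only, one five-membered non-aromatic ring with 1 hetero atom) in place of a group of 9 heavy atoms (8 carbon, 1 nitrogen; one four-membered non-aromatic ring of carbon only, one six-membered non-aromatic ring with 1 hetero atom), on an amide-type nitrogen. The larger group of compound 1 stood on the high side of an at least 9.6-fold lower number from compound 1 to compound 2 (0.98 log units; beyond the scatter), so a rise of smaller size is expected here. The expected step is a 2.9-fold higher number from compound 2 to compound 3 (0.46 log units; beyond the scatter). For compound 3 the estimate is 70000 nM, with an expected range of 22000 nM to 220000 nM.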

Compound 3, half-maximal cytotoxic concentration: 3700 nM
The estimate for compound 3 lay 19-fold (1.28 log units) above the measured number, and the stated range ends above it.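

In this assay, heavy-atom count does not order the groups on the amide-type nitrogen: a 6.5-fold lower number from compound 2 to compound 3 (0.82 log units; beyond the scatter), so the largest group goes with the highest toxicity in this test, whereas the smaller group of compound 2 had stood below compound 1 in toxicity. The widest step at this place is an at least 62-fold lower number from compound 1 to compound 3 (1.79 log units; beyond the scatter). Compound 1 remains a limit of the assay and not a number: the limit of > 233000 nM in this assay, at which 1 of the 3 values shown sits.

On these data alone, it stays open whether the five-membered ring or its added amide-bearing chain goes with the step. A five-membered ring with a free amine, or a carboxylic acid ending that chain, would help separate them.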